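Chloro on the phenoxy group of compound 1

The source may report more compounds than this note shows. Statements on the series, on what has been measured and on what is new or still open speak of the compounds shown alone.

Measured in a functional assay on 4T1 cells (Mus musculus) for cytotoxicity, read by MTT assay, with a stated time of 48 h; a higher number here means a weaker inhibitor, a lower number a stronger inhibitor
compound 1 `COc1ccc(/C=C/C(=O)/C=C/c2cc3ccccc3nc2Oc2ccccc2)cc1OC` gives > 10000 nM
compound 2 `COc1cc(OC)c(OC)cc1/C=C/C(=O)/C=C/c1cc2ccccc2nc1Oc1ccccc1` gives 7630 nM

Compound 1 stands at the limit of > 10000 nM in this assay, at which 1 of the 2 values shown sits, and so gives a limit, not a number. Compound 3 `COc1ccc(/C=C/C(=O)/C=C/c2cc3ccccc3nc2Oc2cccc(Cl)c2)cc1OC` keeps the core of compound 1 and changes phenoxy to 3-chlorophenoxy, chloro in place of hydrogen on an aromatic carbon in this one place. Among the measured compounds shown here, the only measured step, an at least 1.3-fold lower number from compound 1 to compound 2 (0.11 log units; that floor lies within the scatter), is a methoxy in place of hydrogen on an aromatic carbon elsewhere in the molecule, so it bears only loosely on this change. From the compounds shown here alone, no step beyond the scatter is therefore expected in this assay and the direction stays open, with a lower number slightly favoured. The expected step is an at least 1.2-fold lower number from compound 1 to compound 3 (0.09 log units; that floor lies within the scatter) as a working figure. Compound 3 is expected at 8000 nM with 3000 nM to 20000 nM as the estimated range.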

Compound 3, half-maximal inhibitory concentration: > 10000 nM
Compound 3: a limit, no number; the forecaster's own chance of this, stated with the estimate: 45%; at least 1.2-fold (0.09 log units) between middle value and limit.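

In this assay, among the compounds shown here, compound 1 and compound 3 each give only a limit, so no step between them can be read: the limit of > 10000 nM in this assay, at which 2 of the 3 values shown sit. The compounds shown leave open whether chloro in place of hydrogen at this place shifts the number in either direction, and by how much.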